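Phenyl for Methylbenzyl on the Amide Nitrogen

The source may hold more compounds than are shown below. What is called first, only, known or untested is meant among the compounds shown, and "the series" means these compounds.

Compound 1 `C=CC1=C(C(=O)NCc2ccc(C)cc2)C(c2ccc(F)cc2)OC1` was examined in a functional assay on HeLa cells (Homo sapiens) for cytotoxicity, read by MTT assay, with a stated time of 24 h; a higher number here means a weaker inhibitor, a lower number a stronger inhibitor. In this assay compound 1 gives > 100000 nM, which is a limit of the assay rather than a measured number. Two further compounds from the same series share that outcome. Compound 2 `C=CC1=C(C(=O)NCCC)C(c2ccc(Cl)c(Cl)c2)OC1` gives > 100000 nM in this assay, also a limit. Compound 3 `C=CC1=C(C(=O)NC(C)(C)C)C(c2ccc(OC)cc2)OC1` gives > 100000 nM, once more a limit. Compound 1 therefore stands at no distinct place among the values shown, because every result so far sits at the limit of > 100000 nM in this assay, at which 3 of the 3 values shown sit.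

Compound 4 `C=CC1=C(C(=O)Nc2ccccc2)C(c2ccc(F)cc2)OC1` differs from compound 1 in a single place: phenyl in place of 4-methylbenzyl on an amide-type nitrogen. For the measured compounds named here, no step between measured compounds exists in these data, so the effect of the change cannot be read from any comparison. The expectation is that compound 4 shows no step beyond the scatter, with an estimated step from compound 1 to compound 4 of a step that the limit leaves unreadable from compound 1 to compound 4. Compound 4 is accordingly expected at about 150000 nM, within a range of 40000 nM to 600000 nM, and most probably reported only as a limit.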

Compound 4, half-maximal inhibitory concentration: > 100000 nM
Compound 4 ended at the assay's limit; the forecaster's own chance of this, stated with the estimate: 85%; the middle value lies beyond the limit too.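

No step can be read between compound 1 and compound 4, since both results are limits of the assay and not numbers: the limit of > 100000 nM in this assay, at which 4 of the 4 values shown sit.

The compounds shown leave open which change to the shared core, if any, would give a value that can be read as a number.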